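Replacing an aromatic ring with a branched chain

The source may hold more compounds than are shown below. What is called first, only, known or untested is meant among the compounds shown, and "the series" means these compounds.

Three compounds have been measured in an in vitro assay on Ltk- cells for binding affinity to corticotropin-releasing factor receptor 1 (Homo sapiens); a higher number here means a weaker inhibitor, a lower number a stronger inhibitor:

compound 1 `CCC(c1ccccc1)N(CC)c1nc(-c2ccc(Cl)cc2OC)n(C)n1` gives 150 nM
compound 2 `CCCN(c1nc(-c2ccc(Cl)cc2OC)n(C)n1)C(CC)c1ccc(C(F)(F)F)cc1` gives 12 nM
compound 3 `CCCN(c1nc(-c2ccc(Cl)cc2OC)n(C)n1)C(CC)c1ccccc1` gives 26 nM

Compound 3 sits in the middle of these three numbers: its nearest neighbour is compound 2, with a 2.2-fold higher number from compound 2 to compound 3 (0.34 log units; beyond the scatter), and the furthest is compound 1, with a 5.8-fold lower number from compound 1 to compound 3 (0.76 log units; beyond the scatter). The next compound, compound 4 `CCCN(c1nc(-c2ccc(Cl)cc2OC)n(C)n1)C(C(C)C)C(C)C`, changes compound 3 as follows: 1-isopropyl-2-methylpropyl in place of 1-phenylpropyl on a nitrogen on an aromatic ring. Neither measured step covers this kind of change. The step from compound 1 to compound 3 varied the chain on the nitrogen, and the step from compound 2 to compound 3 varied a group on the aromatic ring; both were modest. The aromatic ring itself is kept in every measured compound, so there is no direct guide to removing it. The expectation is therefore a weakening, with wide uncertainty, as a 2.7-fold higher number from compound 3 to compound 4 (0.43 log units; beyond the scatter). Compound 4 is estimated at 70 nM, within a range from 15 nM to 400 nM in this assay.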

Compound 4, inhibition constant: 910 nM
Compound 4: middle estimate off by 13-fold (1.11 log units), on the low side; the measured number lies above the stated range.
By their numbers in this assay, from the lowest: compound 2; then compound 3; then compound 1; then compound 4.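

In this assay, within the data shown here, this is the first step that removes the aromatic ring from this group on the nitrogen, and it gives a 35-fold higher number from compound 3 to compound 4 (1.54 log units; beyond the scatter), a large step where the two earlier ones were modest. The change swaps 9 heavy atoms with one ring for 7 heavy atoms with no ring, so ring loss and the new branching arrive together and this single step cannot separate them. Nothing available here accounts for the size of this rise.

On these data alone, it remains open whether an aromatic ring is needed or simply any ring, which a 1-cyclohexylpropyl group in the same place would help to test. As far as these compounds go, it is also open how a straight-chain group without branching, such as 1-ethylbutyl's unbranched relative heptyl, would compare with compound 3.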